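The source may report more compounds than this note shows. Statements on the series, on what has been measured and on what is new or still open speak of the compounds shown alone.

Compound 1, `CS(=O)(=O)c1cc(C(=O)N=C(N)N)ccc1C#N`, in a functional assay for inhibition of sodium/hydrogen exchanger (Oryctolagus cuniculus) (a higher number here means a weaker inhibitor, a lower number a stronger inhibitor), gives 140 nM. Compound 2, `CS(=O)(=O)c1cc(C(=O)N=C(N)N)ccc1Cl`, gives 380 nM in this assay.

Among the compounds with values here, compound 2 stands with the higher of the two numbers so far; the step of a 2.7-fold higher number from compound 1 to compound 2 (0.43 log units; beyond the scatter) separates it from compound 1. Compound 3, `CS(=O)(=O)c1cc(C(=O)N=C(N)N)ccc1N1CCCCC1`, differs from compound 2 in one place: piperidin-1-yl in place of chloro on an aromatic carbon. The newcomer sits on an aromatic carbon of a six-membered aromatic ring of carbon only, ortho to a methylsulfonyl group and para to a group of 6 heavy atoms. Within the data shown here, no measured step swaps chloro for piperidin-1-yl, so nothing bears on it directly. Among the measured compounds shown here, the only measured step, a 2.7-fold higher number from compound 1 to compound 2 (0.43 log units; beyond the scatter), shows that changing this one position moves the number by a modest amount. A step of similar or somewhat larger size is therefore expected, its direction uncertain but more likely toward a higher number. For compound 3 an estimate of 500 nM is given, with a range from 150 nM to 1800 nM, which corresponds to an expected step of a 1.3-fold higher number from compound 2 to compound 3 (0.12 log units; within the scatter).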

Compound 3, half-maximal inhibitory concentration: 130 nM
Compound 3: the middle estimate sits 3.8-fold (0.59 log units) above what was measured, and the stated range ends above it.
By their numbers in this assay, from the lowest: compounds 3 and 1 (each within the scatter of the next); then compound 2.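

Replacing chloro with piperidin-1-yl gives a 2.9-fold lower number from compound 2 to compound 3 (0.47 log units; beyond the scatter) in this assay, so this position accepts a ring of 6 heavy atoms, and a group far larger than chloro does not weaken inhibition here. Set against the nitrile, the same group gives a 1.1-fold lower number from compound 1 to compound 3 (0.03 log units; within the scatter) and so no readable difference, which leaves chloro apart from the other two and shows that size alone does not order these three groups. Nothing at hand accounts for this result.

Still open, as far as these compounds go, is whether the whole ring matters or only the nitrogen attached to the aromatic carbon, which a small dimethylamino group could help separate. Also open, from the compounds shown here alone, is how a morpholine ring or a carboxylic acid would behave at this place.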